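A Smaller Alkene Tail on the Triple Bond

The source may hold more compounds than are shown below. What is called first, only, known or untested is meant among the compounds shown, and "the series" means these compounds.

Two compounds share one core and differ only in the group on the triple-bonded carbon. Compound 1 `C/C=C\C#Cc1ccc(CCC(=O)O)c(F)c1` carries prop-1-en-1-yl and in a functional assay on 1321-N1 cells for agonist activity at Free fatty acid receptor 1 (Homo sapiens), read by calcium flux, with a stated time of 0.4 s (a lower number here means that less compound is needed, a higher number that more compound is needed for the effect), compound 1 gives 47.9 nM. Compound 2 `C/C=C(\C)C#Cc1ccc(CCC(=O)O)c(F)c1` carries 1-methylprop-1-en-1-yl and in this assay compound 2 gives 37.2 nM. The step of a 1.3-fold lower number from compound 1 to compound 2 (0.11 log units; within the scatter) is the only measured one, and it stays within the scatter, so the two numbers cannot be told apart. Compound 2 therefore holds the lower of the two numbers without standing apart from compound 1.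

Compound 3 `C/C=C/C#Cc1ccc(CCC(=O)O)c(F)c1` is not yet measured. The change from compound 2 to compound 3 is prop-1-en-1-yl in place of 1-methylprop-1-en-1-yl on a triple-bonded carbon. The group that enters bears the same name as the group on compound 1, although the two structures are not identical. Within the data shown here, the step from compound 1 to compound 2 was small, and its reverse direction is the only guide here, so the expected step of a 1.3-fold higher number from compound 2 to compound 3 (0.13 log units; within the scatter) is none beyond the scatter. Compound 3 is expected to give about 50 nM, with a likely range from 20 nM to 125 nM.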

Compound 3, half-maximal effective concentration: 209 nM
Beside the measured number, compound 3's estimate is 4.2-fold (0.62 log units) below it; measured number above the stated range.
By their numbers in this assay, from the lowest: compounds 2 and 1 (each within the scatter of the next); then compound 3.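

In this assay, changing only the drawn geometry of the double bond gives a 4.4-fold higher number from compound 1 to compound 3 (0.64 log units; beyond the scatter), so at this position the group's name alone does not settle the outcome. This is the cleanest comparison in the set, as a single difference separates the pair: the fact that compounds 1 and 3 differ only in the configuration as drawn

The exchange of 1-methylprop-1-en-1-yl for prop-1-en-1-yl gives a 5.6-fold higher number from compound 2 to compound 3 (0.75 log units; beyond the scatter), while the same two group names separate compound 1 and compound 2 by a step within the scatter, so the size of this exchange depends on which drawn form of prop-1-en-1-yl enters.

The compounds shown leave open whether the drawn geometry would matter as much in 1-methylprop-1-en-1-yl, since only one form of that group appears here. They also leave open how a saturated propyl chain, a longer alkene chain or a cyclopropyl ring on the triple-bonded carbon would compare with these three compounds, and why the drawn geometry changes the number so much.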